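The source may report more compounds than this note shows. Statements on the series, on what has been measured and on what is new or still open speak of the compounds shown alone.

Measured so far in a physicochemical assay for lipophilicity, read by HPLC, using the shake flask method; a higher number here means a more lipophilic compound, a lower number a more polar compound:
compound 1 `CCCN(Cc1ccc(Cl)nc1)/C(C)=N/C#N` gives 1.62
compound 2 `CCCCN(Cc1ccc(Cl)nc1)/C(C)=N/C#N` gives 2.13
compound 3 `CCN(Cc1ccc(Cl)nc1)/C(C)=N/C#N` gives 1.19

Compound 3 stands lowest of the three: a number 0.43 log units lower from compound 1 to compound 3 (beyond the scatter) and a number 0.94 log units lower from compound 2 to compound 3 (beyond the scatter), both beyond the scatter. Compound 4 `C=CCN(Cc1ccc(Cl)nc1)/C(C)=N/C#N` differs from compound 3 by vinyl in place of methyl on a saturated chain carbon bound to an amine nitrogen. Among the measured compounds shown here, the steps that bear on it are those in which the chain changed by one carbon: a number 0.51 log units higher from compound 1 to compound 2 (beyond the scatter), and a number 0.43 log units lower from compound 1 to compound 3 (beyond the scatter), where one carbon left. Both are modest and beyond the scatter. For the measured compounds named here, no measured step shows a vinyl entering; the expectation rests on those one-carbon steps and is set somewhat below them, as a rise in this assay expected to remain beyond the scatter. Compound 4 is therefore estimated at 1.4 (range 1.15 to 1.65), an expected step of a number 0.21 log units higher from compound 3 to compound 4 (within the scatter).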

Compound 4, partition coefficient: 1.56
Compound 4: middle estimate off by 0.16 log units, on the low side, within the range that was stated.
By their numbers in this assay, from the lowest: compound 3; then compounds 4 and 1 (each within the scatter of the next); then compound 2.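

In this assay, vinyl in place of methyl at this position reads as a number 0.37 log units higher from compound 3 to compound 4 (beyond the scatter) and so counts as a real step. Vinyl in place of ethyl reads as a number 0.06 log units lower from compound 1 to compound 4 (within the scatter), so the allyl chain of compound 4 and the saturated chain of compound 1 cannot be told apart here, while vinyl in place of propyl still reads as a number 0.57 log units lower from compound 2 to compound 4 (beyond the scatter). Nothing available explains these steps. From the compounds shown here alone, whether a branched chain, a cyclopropylmethyl group or a propargyl group on this amine nitrogen would fall on the same numbers remains open.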